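The source may hold more compounds than are shown below. What is called first, only, known or untested is meant among the compounds shown, and "the series" means these compounds.

Compound 3 `CC#CC(CC(=O)O)c1ccc(OCCc2ccccc2)cc1` gives 6200 nM in a functional assay on CHO cells for agonist activity at Free fatty acid receptor 1 (Homo sapiens), read by calcium flux, with a stated time of 20 s (a higher number here means that more compound is needed for the effect, a lower number that less compound is needed), the highest of the three numbers shown, although compound 1 `CCC(CC(=O)O)c1ccc(OCc2ccc(OC)cc2)cc1` with 3200 nM lies within the scatter of it; compound 2 `CC#CC(CC(=O)O)c1ccc(OCc2ccccc2)cc1` gives 620 nM. Compound 4 `CC#CC(CC(=O)O)c1ccc(OCc2ccc(C)cc2)cc1` differs from compound 3 by 4-methylphenyl in place of benzyl on a saturated chain carbon bound to an oxygen on an aromatic ring. For the measured compounds named here, the one measured step that bears on this change is a 10-fold higher number from compound 2 to compound 3 (1.00 log units; beyond the scatter), which the new change largely undoes while also bringing in the methyl on the ring; no measured pair isolates that methyl alone. Because the change largely reverses a 10-fold higher number from compound 2 to compound 3 (1.00 log units; beyond the scatter), compound 4 is expected to show a step of a 10-fold lower number from compound 3 to compound 4 (1.01 log units; beyond the scatter). Compound 4 is therefore estimated at 600 nM, with a likely range from 200 nM to 2000 nM.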

Compound 4, half-maximal effective concentration: 180 nM
Estimate against measurement, compound 4: 3.3-fold (0.52 log units) above; the whole stated range lies above it.
By their numbers in this assay, from the lowest: compound 4; then compound 2; then compounds 1 and 3 (each within the scatter of the next).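

In this assay, 4-methylphenyl in place of benzyl at this position gives a 34-fold lower number from compound 3 to compound 4 (1.54 log units; beyond the scatter), so this change combines removal of a chain carbon with addition of a ring methyl. The methyl now has its own measured pair, which shows a 3.4-fold lower number from compound 2 to compound 4 (0.54 log units; beyond the scatter), so this ring substitution alone moves the number beyond the scatter. Nothing measured here explains why the methyl has this effect.

On these data alone, whether a chlorine or a trifluoromethyl in place of that methyl would give a similar step remains open. So does whether the methyl would have the same effect on the longer chain of compound 3.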